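The compounds below may be only part of what the source reports. "The series", "measured", "known", "first", "only" and "open" are said of these compounds alone.

Measured so far in an ADME assay on HL-60 cells (Homo sapiens) for cytotoxicity, read by MTT assay, with a stated time of 24 h (a higher number here means a weaker inhibitor, a lower number a stronger inhibitor), and each entry a limit of the assay:
- Compound 1 `CC(C)CCN(C)Cc1ccc(C2=CCCN(C)C2)cc1` gives > 50000 nM as a limit.
- Compound 2 `CC(C)CCCN(C)Cc1ccc(C2=CCCN(C)C2)cc1` gives > 50000 nM as a limit.
- Compound 3 `COc1ccc(CN(C)Cc2ccc(C3=CCCN(C)C3)cc2)cc1` gives > 50000 nM as a limit.

Compound 3 therefore stands on a limit and not on a number, and it shares the limit of > 50000 nM in this assay, at which 3 of the 3 values shown sit, with compound 1 and compound 2.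

Compound 4 `CN1CCC=C(c2ccc(CN(C)C/C=C/c3ccccc3)cc2)C1` has 2-phenylethenyl in place of 4-methoxyphenyl on a saturated chain carbon bound to an amine nitrogen and is otherwise unchanged from compound 3.

The nearest measured changes at this carbon are a step that the two limits leave unreadable from compound 1 to compound 3 and a step that the two limits leave unreadable from compound 2 to compound 3 while the chain change is a step that the two limits leave unreadable from compound 1 to compound 2 and none of the three has a readable size. The only ground for an expectation is that compound 3 and both others sit at the limit of > 50000 nM in this assay, at which 3 of the 3 values shown sit, without exception.

The expected step is a number no higher from compound 3 to compound 4 (the limit leaves the size open) in this assay with no shift beyond the scatter expected in either direction. The estimate for compound 4 is 50000 nM within an expected range of 20000 nM to 100000 nM and a further limit is the likeliest report.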

Compound 4, half-maximal inhibitory concentration: > 50000 nM
Compound 4: no number, only a limit (the forecaster's own chance of this, stated with the estimate: 80%); the middle value sits exactly at the limit.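

In this assay, among these compounds, compound 4 gives > 50000 nM as a limit, so no step from compound 1, compound 2 or compound 3 to compound 4 can be read, and the series stands at: the limit of > 50000 nM in this assay, at which 4 of the 4 values shown sit.

The compounds shown leave open whether any group on this saturated chain carbon bound to an amine nitrogen gives a number in this assay at all.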